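A few compounds are considered here, and "the series" means these few. Any claim that something is new, unique, unknown or untested is made for them only; others in the source may bear on it.

Measured so far in an assay for inhibition of kynurenine 3-monooxygenase (Rattus norvegicus), tested at 10 uM; on this read-out higher numbers stand for more inhibition at the one concentration tested (going by the name of the read-out) and lower numbers for less inhibition:
compound 1 `COC(=O)C(=O)/C=C(\O)c1ccccc1Cl` gives 31%
compound 2 `COC(=O)C(=O)/C=C(\O)c1ccc(F)cc1` gives 22%
compound 3 `COC(=O)C(=O)/C=C(\O)c1cccc(Cl)c1Cl` gives 14%

Compound 3 has the lowest of the three numbers. For the measured compounds named here, its gap to compound 2 is within the usual scatter of repeated measurements, so the two cannot be told apart; its gap to compound 1 lies beyond that scatter, and the one single-change step among the measured compounds, a number 17 percentage points lower from compound 1 to compound 3 (beyond the scatter), is exactly that drop, produced by chloro in place of hydrogen on an aromatic carbon.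

Compound 4 `O=C(O)C(=O)/C=C(\O)c1cccc(Cl)c1Cl` differs from compound 3 in one place: hydrogen in place of methyl on an oxygen next to a carbonyl group. The methyl leaves from an oxygen next to a carbonyl group whose other neighbour is a carbonyl carbon, and hydrogen enters, so the methoxycarbonyl becomes a carboxy group. Going by the values given here, none of the measured steps touches this part of the shared core; the only measured step, a number 17 percentage points lower from compound 1 to compound 3 (beyond the scatter), concerns chloro on an aromatic carbon and says nothing about the methoxycarbonyl. With no guide from the data, the expected step in this assay is none beyond the scatter, which means an estimated a number 4 percentage points higher from compound 3 to compound 4 (within the scatter). Compound 4 is therefore estimated at 18%, in a range from 2% to 40%.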

Compound 4, a percentage reported as inhibition, at one concentration (the size of the read-out at that concentration, not a potency): 33%
Beside the measured number, compound 4's estimate is 15 percentage points below it; measured number inside the range.
By their numbers in this assay, from the lowest: compounds 3, 2, 1 and 4 (each within the scatter of the next, the first and the last beyond it).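

In this assay, the methoxycarbonyl part of the shared core proves sensitive to change: hydrogen in place of methyl, which turns it into a carboxy group, gives a number 19 percentage points higher from compound 3 to compound 4 (beyond the scatter) and moves the number beyond the scatter. For the compounds shown here, this is the first measured step at this part of the core, as the earlier step, a number 17 percentage points lower from compound 1 to compound 3 (beyond the scatter), concerned chloro on an aromatic carbon. Going by these compounds alone, the two steps run in opposite directions, so changes at these two places can each move the number, though this change has been read on only one pair of compounds.

From the compounds shown here alone, whether the same change would raise the number on compound 1 or compound 2 stays open, as does what an ethoxycarbonyl or a carboxamide group would give at this place. Nothing measured here explains the rise.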